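A bulkier, hydroxy-bearing amide partner for compound 1

This account rests on a few compounds, and the source may have more. Where it says the series, first, only, none or still open, it means among the compounds named here.

Compound 1 `COc1cc(C(=O)N2CCCC2(C)C)cc2nc(NCc3cccc(Cl)c3)oc12` is measured in an assay on isolated protein for inhibition of thyroid hormone receptor beta (Homo sapiens), read by fluorescence, with a stated time of 30 min (a higher number here means a weaker inhibitor, a lower number a stronger inhibitor), where compound 1 gives 47 nM, the lowest of the two numbers recorded. Compound 2 `COc1cc(C(=O)N2CCC(O)C(C)C2)cc2oc(NCc3cccc(Cl)c3)nc12` differs from compound 1 in more than one place; in this assay compound 2 gives 3900 nM. Compound 3 `CCC1CC(O)C(C)CN1C(=O)c1cc(OC)c2oc(NCc3cccc(Cl)c3)nc2c1` is not yet measured. It differs from compound 1 by 2-ethyl-4-hydroxy-5-methylpiperidin-1-yl in place of 2,2-dimethylpyrrolidin-1-yl on a carbonyl carbon. With no single-change comparison available, a modest weakening is expected, beyond the scatter but far short of the gap to compound 2. For compound 3 the estimate in this assay is 200 nM, within 40 nM to 1500 nM, which is an expected step of a 4.3-fold higher number from compound 1 to compound 3 (0.63 log units; beyond the scatter).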

Compound 3, half-maximal inhibitory concentration: 13 nM
Beside the measured number, compound 3's estimate is 15-fold (1.19 log units) above it; measured number outside the range, below it.
By their numbers in this assay, from the lowest: compound 3; then compound 1; then compound 2.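

On the carbonyl carbon, 2-ethyl-4-hydroxy-5-methylpiperidin-1-yl can replace 2,2-dimethylpyrrolidin-1-yl without any loss in this assay; the swap gives a modest gain (a 3.6-fold lower number from compound 1 to compound 3 (0.56 log units; beyond the scatter)). This position therefore accepts a six-membered ring with more heavy atoms and a hydrogen-bond donor. No measurement shown here gives a reason for the gain.

Ring size, ethyl, hydroxy and methyl all change together, so which of them matters remains open. On these data alone, whether an amine or a carboxylic acid could replace the hydroxy also remains open.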